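This account rests on a few compounds, and the source may have more. Where it says the series, first, only, none or still open, it means among the compounds named here.

Measured so far: compound 1 `COC(=O)c1c(Nc2ccccc2)sc(C(=O)c2ccc(OC)cc2)c1C` gives 32.4%; compound 2 `COC(=O)c1c(Nc2ccccc2)sc(C(=O)c2ccc(C)cc2)c1C` gives 6.06%; compound 3 `COc1ccc(C(=O)c2sc(Nc3ccc(C)cc3)c(C(=O)O)c2C)cc1` is reported as "not active" (no number reported), with no number.

In a functional assay, with a stated time of 150 min, tested at 20 ug/mL (on this read-out lower numbers stand for a weaker effect and higher numbers for a stronger effect at the one concentration tested), the step of a number 26.3 percentage points higher from compound 2 to compound 1 (beyond the scatter) follows the change (methoxy in place of methyl on an aromatic carbon). Compound 4 `COc1ccc(Nc2sc(C(=O)c3ccc(OC)cc3)c(C)c2C(=O)O)cc1` is not yet measured; it differs from compound 3 by methoxy in place of methyl on an aromatic carbon, the same change at the same kind of place. The difference between the cores of compound 2 and compound 3 is not broken down here. Compound 3 gives no number, so the gain seen from compound 2 to compound 1 can only be carried over with caution. Compound 4 is expected to give a step of similar direction because a number 26.3 percentage points higher from compound 2 to compound 1 (beyond the scatter) was seen for the same change. Compound 4 is estimated at 20%, ranging from 0% to 45%.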

Compound 4, a percentage reported as activity, at one concentration (the size of the read-out at that concentration, not a potency): 32.5%
For compound 4 the middle estimate is 12.5 percentage points below the measured one, within the range that was stated.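

For the compounds shown here, compound 3 carries no number in this assay, so no step to compound 4 can be read. The compounds shown leave open how far methoxy in place of methyl shifts the read-out on the core of compound 4. Nothing shown speaks to a cause for this result.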